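Methoxy on the phenyl rings of an aminothiazole ketone series

This account rests on a few compounds, and the source may have more. Where it says the series, first, only, none or still open, it means among the compounds named here.

Compound 1 `COc1ccc(C(=O)c2sc(Nc3ccccc3)nc2N)cc1OC` gives 6000 nM in a functional assay on HeLa cells (Homo sapiens) for antiproliferative activity, read by cell counting, with a stated time of 2 days; a lower number here means a stronger inhibitor, a higher number a weaker inhibitor. Compound 2 `COc1ccc(Nc2nc(N)c(C(=O)c3ccc(OC)c(OC)c3)s2)cc1` gives 52 nM. The change from compound 1 to compound 2 is methoxy in place of hydrogen on an aromatic carbon, and it brought a 120-fold lower number from compound 1 to compound 2 (2.06 log units; beyond the scatter). For compound 3 `Nc1nc(Nc2ccc(F)cc2)sc1C(=O)c1ccccc1` only a limit of > 10000 nM is recorded in this assay, one of the values sitting at the limit of > 10000 nM in this assay, at which 1 of the 3 values shown sits. How the core of compound 3 differs from the core of compound 1 is not broken down here. Compound 4 `COc1ccc(C(=O)c2sc(Nc3ccc(F)cc3)nc2N)cc1` is not yet measured; it differs from compound 3 by methoxy in place of hydrogen on an aromatic carbon, the place described in the same words as before, so the same change. Among the measured compounds shown here, from compound 3 to compound 4 a step of an at least 3.3-fold lower number from compound 3 to compound 4 (0.52 log units; beyond the scatter) is expected, resting on the single earlier step of this change, though that step began from a core whose relation to compound 3 is not resolved. Compound 4 is therefore estimated at 3000 nM in this assay.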

Compound 4, half-maximal inhibitory concentration: > 10000 nM
Compound 4: no number, only a limit; the forecaster's own chance of this, stated with the estimate: 30%; middle value at least 3.3-fold (0.52 log units) from the limit.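

Compound 3 and compound 4 both give only limits in this assay, so no step between them can be read: the limit of > 10000 nM in this assay, at which 2 of the 4 values shown sit.

Left open is whether methoxy in place of hydrogen changes the number at all on the core of compound 3, as it did between compound 1 and compound 2.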